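A few compounds are considered here, and "the series" means these few. Any claim that something is new, unique, unknown or untested is made for them only; others in the source may bear on it.

Measured compounds:
compound 1 `COc1cc(-c2nn(-c3cccc(NC(=O)c4cccc(C(F)(F)F)c4)c3)cc2-c2ccncc2)ccc1Cl`: > 50000 nM
compound 2 `COc1cc(-c2nn(-c3cccc(NC(=O)Nc4cccc(C(F)(F)F)c4)c3)cc2-c2ccncc2)ccc1Cl`: > 50000 nM
compound 3 `O=C(Nc1cccc(-n2cc(-c3ccncc3)c(-c3ccc(Cl)c(O)c3)n2)c1)Nc1cc(C(F)(F)F)cc(C(F)(F)F)c1`: > 50000 nM

In a functional assay on K562 cells (Homo sapiens) for inhibition, read by sulforhodamine B assay, with a stated time of 48 h (a higher number here means that more compound is tolerated, a lower number that less compound is tolerated), compound 1 gives > 50000 nM, which is a limit of the assay and not a number. Compound 2 likewise stops at a limit, > 50000 nM. Compound 3 also reaches only a limit, > 50000 nM. Compound 1 therefore cannot be ranked within the series; every value shown is a limit (the limit of > 50000 nM in this assay, at which 3 of the 3 values shown sit). The unmeasured compound 4 `COc1cc(-c2nn(-c3cccc(NC(=O)c4ccccc4)c3)cc2-c2ccncc2)ccc1Cl` differs from compound 1 by hydrogen in place of trifluoromethyl on an aromatic carbon. Among the measured compounds shown here, the only single-point step, a step that the two limits leave unreadable from compound 1 to compound 2, is unreadable between two limits, so no size can be carried over. Compound 4 is expected to remain at the limit, with an expected step that the limit leaves unreadable from compound 1 to compound 4. Compound 4 is thus estimated at 60000 nM, within 20000 nM to 200000 nM.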

Compound 4, concentration lethal to 50% of the cells: > 100000 nM
Compound 4: only a limit was reported (the forecaster's own chance of this, stated with the estimate: 85%); middle value at least 1.6-fold (0.22 log units) from the limit.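

Among the compounds shown here, compound 1, compound 2 and compound 4 all stop at limits and not at numbers, so no step among them can be read. Still open, from the compounds shown here alone, is which structural change, if any, gives a measurable value in this assay.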